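The source may report more compounds than this note shows. Statements on the series, on what has been measured and on what is new or still open speak of the compounds shown alone.

Compound 1, whose structure is `ClCc1ccc(Cn2cnc3c(Cl)ncnc32)cc1`, is the starting point of this small set. In a functional assay on HCT-116 cells (Homo sapiens) for cytotoxicity, read by sulforhodamine B assay, with a stated time of 48 h (a higher number here means a weaker inhibitor of growth, a lower number a stronger inhibitor of growth), compound 1 gives 2450 nM. Compound 2, with the structure `Nc1nc(Cl)c2ncn(Cc3ccc(CCl)cc3)c2n1`, carries one extra group on the shared core, and in this assay compound 2 gives 15000 nM. The change from compound 1 to compound 2 is amino in place of hydrogen on an aromatic carbon and it made a step of a 6.1-fold higher number from compound 1 to compound 2 (0.79 log units; beyond the scatter).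

Compound 3 has the structure `ClCc1ccccc1Cn1cnc2c(Cl)ncnc21`. It is built from the same atoms as compound 1, joined differently, and the difference between the two cores is not broken down here. In this assay compound 3 gives 3710 nM; set beside compound 1, the two values lie within the usual scatter, while compound 2 stands clearly apart from both.

Compound 4, whose structure is `Nc1nc(Cl)c2ncn(Cc3ccccc3CCl)c2n1`, is not yet measured. Its difference from compound 3 is amino in place of hydrogen on an aromatic carbon, the same change that turns compound 1 into compound 2, and the surroundings of the place are described in the same words for both pairs. Within the data shown here, since only one earlier example of this change is known, the expectation rests on it alone. The step from compound 3 to compound 4 in this assay is expected to be a 5.4-fold higher number from compound 3 to compound 4 (0.73 log units; beyond the scatter), because compound 1 to compound 2 gave a 6.1-fold higher number from compound 1 to compound 2 (0.79 log units; beyond the scatter). For compound 4 in this assay the estimated value is 20000 nM, expected to fall between 8000 nM and 50000 nM.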

Compound 4, concentration for total growth inhibition: > 100000 nM
Compound 4: only a limit was reported; the forecaster's own chance of this, stated with the estimate: 10%; middle value at least 5.0-fold (0.69 log units) from the limit.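

In this assay, amino in place of hydrogen on an aromatic carbon gave a higher number, a weaker inhibitor of growth, on both cores, with an at least 26-fold higher number from compound 3 to compound 4 (1.43 log units; beyond the scatter), so the direction of the change carried over from the core of compound 1 to the core of compound 3. The size of the step did not carry over, and a single pair on each core cannot show why the two cores answer so differently: the same change on two cores in this assay, a 6.1-fold higher number (0.79 log units; beyond the scatter) from compound 1 to compound 2 and an at least 26-fold higher number (1.43 log units; beyond the scatter) from compound 3 to compound 4, at least 4.4-fold (0.64 log units) apart, beyond the scatter of two such steps Compound 4 gives > 100000 nM, which is a limit of the assay and not a number, so the second step has a lower bound but no exact size: the limit of > 100000 nM in this assay, at which 1 of the 4 values shown sits.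

The compounds shown leave open whether the larger step on the core of compound 3 is tied to amino itself, or whether a methylamino, a hydroxyl or a methoxy group at the same place would also give steps that differ from one core to the other. They also leave open whether the same pattern would hold if the chloro group on the shared core were replaced by a methoxy group.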